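Diethylamino for pyrrolidin-1-yl across two related cores

This account rests on a few compounds, and the source may have more. Where it says the series, first, only, none or still open, it means among the compounds named here.

Three compounds are measured in a functional assay on MGC-803 cells (Homo sapiens) for inhibition (a lower number here means a stronger inhibitor, a higher number a weaker inhibitor), and all three sit at a limit of the assay. Compound 1 `CCN(CC)CCNC(=O)CC(CC(=O)NC1Cc2ccccc2C1)c1ccc(Cl)cc1` gives > 100000 nM, a limit rather than a number. Compound 2 `O=C(CC(CC(=O)NC1Cc2ccccc2C1)c1ccc(Cl)cc1)NCCN1CCCC1` gives > 100000 nM, likewise a limit. Compound 3 `CN(C(=O)CC(CC(=O)NCCN1CCCC1)c1ccccc1)C1Cc2ccccc2C1` gives > 100000 nM, again a limit. Compound 2 and compound 1 differ in one place, (diethylamino in place of pyrrolidin-1-yl on a saturated chain carbon, two bonds along the chain from an amide-type nitrogen), and the step reads a step that the two limits leave unreadable from compound 2 to compound 1, since both values sit at the limit; this is recorded in the limit of > 100000 nM in this assay, at which 3 of the 3 values shown sit. Compound 4 `CCN(CC)CCNC(=O)CC(CC(=O)N(C)C1Cc2ccccc2C1)c1ccccc1` is not yet measured. It differs from compound 3 in one place, (diethylamino in place of pyrrolidin-1-yl on a saturated chain carbon, two bonds along the chain from an amide-type nitrogen), the same change as between compound 2 and compound 1, at the same place. How the core of compound 3 differs from that of compound 2 is not broken down here. Because both ends of the earlier change sit at the limit shown in the limit of > 100000 nM in this assay, at which 3 of the 3 values shown sit, no size can be read from it; compound 3 itself stands only at a limit. The step from compound 3 to compound 4 is expected to be a number no higher from compound 3 to compound 4 (the limit leaves the size open) in this assay. Compound 4 is therefore expected to give about 100000 nM, with a range from 30000 nM to 300000 nM, most likely reported as a limit again.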

Compound 4, half-maximal inhibitory concentration: > 100000 nM
Compound 4: no number, only a limit (the forecaster's own chance of this, stated with the estimate: 85%); the middle value sits exactly at the limit.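

In this assay compound 4 gives > 100000 nM, a limit and not a number. Compound 3 also stands at a limit, and no step can be read between compound 3 and compound 4. The compounds shown leave open what diethylamino in place of pyrrolidin-1-yl does to inhibition, since every value sits at one limit: the limit of > 100000 nM in this assay, at which 4 of the 4 values shown sit.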